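This account rests on a few compounds, and the source may have more. Where it says the series, first, only, none or still open, it means among the compounds named here.

Values measured in a physicochemical assay for solubility, with a stated time of 4 h, at pH 2.0 (a higher number here means a more soluble compound, a lower number a less soluble compound), for the compounds so far:
- compound 1 (`CC(=O)CCc1cc(C)c(Oc2cc(Nc3ccc(C#N)cc3)c(N)cc2C(F)(F)F)c(C)c1`): 0.28 ug/mL
- compound 2 (`Cc1cc(/C=C/C#N)cc(C)c1Oc1cc(Nc2ccc(C#N)cc2)c(N)cc1[N+](=O)[O-]`): 0.29 ug/mL

Compound 2, at 0.29 ug/mL in this assay, lies within the scatter of compound 1 (0.28 ug/mL), so the two numbers cannot be ordered. Both sit at the same low level, and they differ in more than one place, so neither difference can be read on its own.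

The next structure is compound 3 (`CNC(=O)c1cc(N)c(Nc2ccc(C#N)cc2)cc1Oc1c(C)cc(/C=C/C#N)cc1C`), which keeps the rest of compound 2 but carries methylcarbamoyl in place of nitro on an aromatic carbon. The new group stands para to a (4-cyanophenyl)amino group and meta to an amino group.

Among the compounds with values here, no measured pair differs in a single place, so the data give no direct guide to this change, and the only anchor is compound 2 at 0.29 ug/mL in this assay. A modest upward move is expected, though a result within the scatter would not surprise. The expected step is a 2.1-fold higher number from compound 2 to compound 3 (0.32 log units; beyond the scatter), and it remains an estimate with wide uncertainty. Compound 3 is estimated at 0.6 ug/mL (expected range 0.2 ug/mL to 2.5 ug/mL).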

Compound 3, solubility: 8.63 ug/mL
Beside the measured number, compound 3's estimate is 14-fold (1.16 log units) below it, and the stated range ends below it.
By their numbers in this assay, from the lowest: compounds 1 and 2 (each within the scatter of the next); then compound 3.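

In this assay, methylcarbamoyl in place of nitro on an aromatic carbon gives a 30-fold higher number from compound 2 to compound 3 (1.47 log units; beyond the scatter), a large step and the first in the series that can be read at a single place. This position, ortho to a large group, meta to an amino group and para to a (4-cyanophenyl)amino group, is therefore one where a change of substituent alone can move the read-out well beyond the scatter, with the rest of compound 2 held constant; by the counts, nitro leaves with 0 hydrogen-bond donors and 2 hydrogen-bond acceptors, methylcarbamoyl enters with 1 hydrogen-bond donor and 1 hydrogen-bond acceptor, and neither group has a net charge. No measurement at hand explains the size of this step.

As far as these compounds go, how a carboxylic acid, a plain carboxamide or a longer chain on the amide nitrogen would read at this place remains open, so it cannot yet be said which part of methylcarbamoyl matters. Also open, from the compounds shown here alone, is whether methylcarbamoyl in place of trifluoromethyl on the core of compound 1 would give a step of similar size.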